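Cyano for bromo on the isopropoxy-bearing ring

The compounds below may be only part of what the source reports. "The series", "measured", "known", "first", "only" and "open" are said of these compounds alone.

Compound 2 `Cc1cc(CCC(=O)O)ccc1-c1noc(-c2ccc(OC(C)C)c(Br)c2)n1` stands at a limit of a functional assay on CHO cells with sphingosine 1-phosphate receptor 2 (Homo sapiens) as the target, read by GTPgammaS binding; on this read-out lower numbers stand for an effect already at smaller amounts and higher numbers for an effect only at larger amounts of compound: in this assay compound 2 gives > 10000 nM, which is a limit of the assay and not a number. Compound 1 `Cc1cc(CCC(=O)O)ccc1-c1noc(-c2ccc(OC(C)C)c(Cl)c2)n1` likewise gives only a limit in this assay, > 10000 nM. The step that the two limits leave unreadable from compound 1 to compound 2 is therefore not readable in size; what the two values show is the limit of > 10000 nM in this assay, at which 2 of the 2 values shown sit. Compound 3 `Cc1cc(CCC(=O)O)ccc1-c1noc(-c2ccc(OC(C)C)c(C#N)c2)n1` carries the change (cyano in place of bromo on an aromatic carbon). Going by the values given here, no measured step bears on a cyano group, and the single measured step between compound 1 and compound 2 cannot be read, so no direction can be drawn from the numbers. The expected step that the limit leaves unreadable from compound 2 to compound 3 is accordingly estimated as none beyond the scatter, with a limit again the most probable outcome. Compound 3 is expected at 15000 nM, within a range of 3000 nM to 60000 nM.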

Compound 3, half-maximal effective concentration: > 10000 nM
Compound 3 was reported as a limit; the forecaster's own chance of this, stated with the estimate: 80%; the middle value does not contradict the limit.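

Compound 3 also stands at a limit rather than a number, so the steps to it from compound 1 and compound 2 cannot be read in this assay: the limit of > 10000 nM in this assay, at which 3 of the 3 values shown sit. The compounds shown leave open how chloro, bromo and cyano rank at this place on the shared core.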